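Replacing 3-methylthiophen-2-yl with 3-methoxyphenyl on compound 3

The source may hold more compounds than are shown below. What is called first, only, known or untested is meant among the compounds shown, and "the series" means these compounds.

In a functional assay on SK-OV-3 cells (Homo sapiens) for cytotoxicity (a higher number here means a weaker inhibitor, a lower number a stronger inhibitor), compound 1 `C=C/C=C\[C@H](C)[C@H](OC(N)=O)[C@@H](C)[C@H](O)[C@@H](C)C/C(C)=C\[C@H](C)[C@@H](O)[C@@H](C)/C=C\CCc1ccc(C)c(F)c1` gives 1000 nM, compound 2 `C=C/C=C\[C@H](C)[C@H](OC(N)=O)[C@@H](C)[C@H](O)[C@@H](C)C/C(C)=C\[C@H](C)[C@@H](O)[C@@H](C)/C=C\CCc1ccc(C)c(O)c1` gives 410 nM and compound 3 `C=C/C=C\[C@H](C)[C@H](OC(N)=O)[C@@H](C)[C@H](O)[C@@H](C)C/C(C)=C\[C@H](C)[C@@H](O)[C@@H](C)/C=C\CCc1sccc1C` gives 370 nM. Compound 3 stands level with compound 2, given a 1.1-fold lower number from compound 2 to compound 3 (0.04 log units; within the scatter), and clearly under compound 1. Compound 4 `C=C/C=C\[C@H](C)[C@H](OC(N)=O)[C@@H](C)[C@H](O)[C@@H](C)C/C(C)=C\[C@H](C)[C@@H](O)[C@@H](C)/C=C\CCc1cccc(OC)c1` carries 3-methoxyphenyl in place of 3-methylthiophen-2-yl on a saturated chain carbon, two bonds along the chain from a double-bonded chain carbon. The nearest guides are a 2.7-fold lower number from compound 1 to compound 3 (0.43 log units; beyond the scatter), a modest swap of the same kind run the other way, and a 2.4-fold lower number from compound 1 to compound 2 (0.39 log units; beyond the scatter), also modest. A similarly modest or smaller step toward a higher number is therefore expected: a 1.6-fold higher number from compound 3 to compound 4 (0.21 log units; within the scatter). The estimate for compound 4 is 600 nM, within an expected range of 250 nM to 1500 nM.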

Compound 4, half-maximal inhibitory concentration: 370 nM
Compound 4: middle estimate off by 1.6-fold (0.21 log units), on the high side, within the range that was stated.
By their numbers in this assay, from the lowest: compounds 3, 4 and 2 (each within the scatter of the next); then compound 1.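

In this assay, a six-membered carbon ring bearing methoxy serves at this position as well as the five-membered sulfur ring (no change at the digits printed from compound 3 to compound 4 (within the scatter)). It also matches 3-hydroxy-4-methylphenyl (a 1.1-fold lower number from compound 2 to compound 4 (0.04 log units; within the scatter)), whereas 3-fluoro-4-methylphenyl remains the outlier (a 2.7-fold lower number from compound 1 to compound 4 (0.43 log units; beyond the scatter)). No supporting evidence is available to explain these results. The compounds shown leave open whether an amine or a carboxylic acid in place of the methoxy group would keep this level.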